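A few compounds are considered here, and "the series" means these few. Any claim that something is new, unique, unknown or untested is made for them only; others in the source may bear on it.

Compound 3 `O=C(O)c1ccccc1-c1ccc(CCc2ncc(-c3ccccc3)[nH]2)cc1` stands second highest among three compounds tested in an in vitro functional assay on cells for agonist activity at Bombesin receptor subtype-3 (Homo sapiens), read by luminescence and calcium flux; a higher number here means that more compound is needed for the effect, a lower number that less compound is needed: compound 3 gives 4950 nM, compound 2 `N#Cc1ccc(Cc2cnc(CCc3ccc(-c4ccccc4C(=O)O)cc3)[nH]2)cc1` gives 5890 nM, which lies within the scatter of compound 3, and compound 1 `Cc1ccccc1Cc1cnc(CCc2ccc(-c3ccccc3C(=O)O)cc2)[nH]1` gives 127 nM. The two steps that lead to compound 3 were a 39-fold higher number from compound 1 to compound 3 (1.59 log units; beyond the scatter) and a 1.2-fold lower number from compound 2 to compound 3 (0.08 log units; within the scatter), so within these three compounds the group on the five-membered ring matters greatly, and the 2-methylbenzyl of compound 1 does far better than phenyl or 4-cyanobenzyl. Compound 4 `O=C(O)c1ccccc1-c1ccc(CCc2ncc(CC3CC3)[nH]2)cc1` makes the change (cyclopropylmethyl in place of phenyl on an aromatic carbon). Going by the values given here, no measured step covers a cyclopropylmethyl here, so the expected step of a 2.5-fold lower number from compound 3 to compound 4 (0.39 log units; beyond the scatter) is a modest improvement with wide uncertainty. The estimate for compound 4 is 2000 nM, ranging from 400 nM to 10000 nM.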

Compound 4, half-maximal effective concentration: 1000 nM
The estimate for compound 4 lay 2.0-fold (0.30 log units) above the measured number; low and high end bracket the measured number.
By their numbers in this assay, from the lowest: compound 1; then compound 4; then compounds 3 and 2 (each within the scatter of the next).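

Swapping phenyl for cyclopropylmethyl gives a 5.0-fold lower number from compound 3 to compound 4 (0.69 log units; beyond the scatter) and shows that a group on this aromatic carbon needs no aromatic ring to do better than phenyl. With the chain carbon kept, cyclopropyl beats 4-cyanophenyl with a 5.9-fold lower number from compound 2 to compound 4 (0.77 log units; beyond the scatter) but falls short of 2-methylphenyl with a 7.9-fold higher number from compound 1 to compound 4 (0.90 log units; beyond the scatter) and so leaves compound 1 ahead of compound 4. No measurement here explains these steps. Still open, from the compounds shown here alone, is whether a larger saturated ring, as in cyclohexylmethyl, or an amine-bearing group such as piperidinylmethyl, would match the 2-methylbenzyl of compound 1.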